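Series notes: side-chain exchange and expected cytotoxicity

A few compounds are considered here, and "the series" means these few. Any claim that something is new, unique, unknown or untested is made for them only; others in the source may bear on it.

Compound 1 `COc1cc(C(c2ccc(O)c(OC)c2)[C@@H](C)[C@@H](C)CO)ccc1O` and its mirror image compound 2 `COc1cc(C(c2ccc(O)c(OC)c2)[C@H](C)[C@H](C)CO)ccc1O` form the measured pair. In a functional assay on HL-60 cells (Homo sapiens) for cytotoxicity, read by WST assay, with a stated time of 48 h (a lower number here means a stronger inhibitor, a higher number a weaker inhibitor), compound 1 gives only a limit, > 100000 nM. Compound 2 likewise reaches only a limit in this assay, > 100000 nM. The step that the two limits leave unreadable from compound 1 to compound 2 therefore cannot be read; both values sit at the limit, as shown by the limit of > 100000 nM in this assay, at which 2 of the 2 values shown sit, and the two compounds differ only in configuration as drawn, (the fact that compounds 1 and 2 differ only in the configuration as drawn). Compound 1 thus stands at the limit of this assay, with no measured number that would rank it against anything.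

For the measured compounds named here, compound 3 `CCCCC[C@H](C(C)C)C(c1ccc(O)c(OC)c1)c1ccc(O)c(OC)c1` is the next candidate. 1-isopropylhexyl in place of 2-(hydroxymethyl)-1-methylpropyl on a saturated chain carbon bound to two aromatic carbons The single measured step, from compound 1 to compound 2, bears on it only as a sign that configuration alone did not move either compound off the limit. Going by the values given here, no measured step speaks to the exchange of the chain itself, so the expected step of an at least 1.2-fold lower number from compound 1 to compound 3 (0.09 log units; that floor lies within the scatter) rests on no calibrated comparison. Compound 3 is expected to remain near the limit of this assay, at an estimated 80000 nM with a range from 20000 nM to 300000 nM.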

Compound 3, half-maximal inhibitory concentration: 9600 nM
Compound 3: the middle estimate sits 8.3-fold (0.92 log units) above what was measured, and the stated range ends above it.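

At the saturated chain carbon bound to two aromatic carbons, 1-isopropylhexyl in place of 2-(hydroxymethyl)-1-methylpropyl gives, in this assay, an at least 10-fold lower number from compound 1 to compound 3 (1.01 log units; beyond the scatter), and likewise an at least 10-fold lower number from compound 2 to compound 3 (1.01 log units; beyond the scatter). For the compounds shown here, the mirror-image pair showed no readable difference, so this exchange of the chain is the first change to yield a value that is a number rather than a limit: the limit of > 100000 nM in this assay, at which 2 of the 3 values shown sit. Going by these compounds alone, both steps are floors whose full size cannot be read, and the one exchange changes several counted features together, with 6 heavy atoms leaving and 9 entering, the hydrogen-bond donor and acceptor of the leaving group gone, and the defined stereocentres going from 2 to 1.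

The compounds shown leave open whether the step follows the loss of the hydroxyl or the larger carbon chain, a question that a 1-isopropylhexyl chain carrying a hydroxyl, or an amine, would bear on directly. Also open, on these data alone, are how a longer chain at this place would read and whether the mirror image of compound 3 would read differently in this assay.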